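This account rests on a few compounds, and the source may have more. Where it says the series, first, only, none or still open, it means among the compounds named here.

Three related compounds share one core and have been tested in an ADME assay on a cell-free system (plasma, Homo sapiens) for protein binding; on this read-out lower numbers stand for a smaller free fraction and higher numbers for a larger free fraction. Compound 1 `Cc1ccc(-c2cnc(C)n2C)cc1NC(=O)c1ccc(OCc2ccccn2)cc1` gives 0.19, compound 2 `Cc1cc(C)c(-c2cn(C)cn2)cc1NC(=O)c1ccc(OCc2ccccn2)cc1` gives 0.055, and compound 3 `Cc1ncc(-c2cc(NC(=O)c3ccc(OCc4ccccn4)cc3)c(C)cc2C)[nH]1` gives 0.095. Compound 3 lies within the scatter of both compound 2 and compound 1, so the three numbers cannot be told apart. Compound 4 `Cc1cc(C)c(-c2ccc(N)nn2)cc1NC(=O)c1ccc(OCc2ccccn2)cc1` is not yet measured; it differs from compound 3 in one place: 6-aminopyridazin-3-yl in place of 2-methyl-1H-imidazol-5-yl on an aromatic carbon. Going by the values given here, the only step that bears on it, a 1.7-fold higher number from compound 2 to compound 3 (0.24 log units; within the scatter), swapped one five-membered aromatic ring for another at that spot and stayed within the scatter. Among the compounds with values here, no measured step covers a six-membered aromatic ring there, so the expectation rests on that single swap. The step is therefore expected to be a 1.1-fold higher number from compound 3 to compound 4 (0.02 log units; within the scatter). Compound 4 is thus estimated at 0.1, within 0.04 to 0.25.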

Compound 4, unbound fraction: 0.064
The estimate for compound 4 lay 1.6-fold (0.19 log units) above the measured number; measured number inside the range.
By their numbers in this assay, from the lowest: compounds 2, 4, 3 and 1 (each within the scatter of the next, the first and the last beyond it).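

The 6-aminopyridazin-3-yl group shows that a six-membered aromatic ring can sit on this aromatic carbon and stay within the scatter of both five-membered rings in this assay (a 1.5-fold lower number from compound 3 to compound 4 (0.17 log units; within the scatter); a 1.2-fold higher number from compound 2 to compound 4 (0.07 log units; within the scatter)). Across compound 2, compound 3 and compound 4, ring size at this position therefore makes no readable difference to the free fraction. Nothing measured here offers an explanation for this.

Still open, going by these compounds, is whether a group without a ring at this position, such as a carboxylic acid or a longer chain ending in an amine, would move the number beyond the scatter.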